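A Second Chloro on Compound 3

The compounds below may be only part of what the source reports. "The series", "measured", "known", "first", "only" and "open" are said of these compounds alone.

Three compounds that share one core have numbers in a functional assay on HepG2 cells (Homo sapiens) for cytotoxicity, read by MTT assay, with a stated time of 24 h (a lower number here means a stronger inhibitor, a higher number a weaker inhibitor), so far. In that test compound 1 (`COc1ccc(/C=C2\CN(C)C/C(=C\c3ccccc3F)C2=O)cc1`) gives 12300 nM while compound 2 (`COc1cc(/C=C2\CN(C)C/C(=C\c3ccc(Cl)cc3)C2=O)cc(OC)c1OC`) gives 8250 nM and compound 3 (`CN1C/C(=C\c2ccc(Cl)cc2)C(=O)/C(=C/c2cccc([N+](=O)[O-])c2)C1`) gives 8210 nM there. Compound 3 therefore lies within the scatter of both others, and the three cannot be ranked.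

Compound 4 (`CN1C/C(=C\c2cccc([N+](=O)[O-])c2)C(=O)/C(=C/c2ccc(Cl)c(Cl)c2)C1`) follows from compound 3 by one change (chloro in place of hydrogen on an aromatic carbon) that puts chloro in place of hydrogen on an aromatic carbon, ortho to a chloro group, turning 4-chlorophenyl to 3,4-dichlorophenyl. Going by the values given here, no measured pair differs in one place only, so no direct precedent exists. Different groups on the shared core still leave compound 1 at 12300 nM and compound 3 at 8210 nM within the scatter of each other, so little movement seems likely. The expected step of a 1.4-fold lower number from compound 3 to compound 4 (0.14 log units; within the scatter) is small, toward a lower number and within the scatter. In this assay the estimate for compound 4 is 6000 nM with an expected range from 2500 nM to 12000 nM as the likely span.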

Compound 4, half-maximal inhibitory concentration: 5960 nM
For compound 4 the middle estimate is 1.0-fold (0.00 log units) above the measured one; the range from low to high includes it.
By their numbers in this assay, from the lowest: compounds 4, 3, 2 and 1 (each within the scatter of the next, the first and the last beyond it).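

Going by these compounds alone, the change from 4-chlorophenyl to 3,4-dichlorophenyl gives, in this assay, a 1.4-fold lower number from compound 3 to compound 4 (0.14 log units; within the scatter), and this is the first step in the set that isolates a single place on the shared core. Within the data shown here, it shows that chloro in place of hydrogen on this aromatic carbon, ortho to a chloro group, does not move the number beyond the scatter, something the earlier comparisons of compounds differing in several places could not show. Nothing measured here bears on why the step has this size.

From the compounds shown here alone, whether an amine or a carboxylic acid on the same aromatic carbon would give a step beyond the scatter remains open. Also open, going by these compounds, is whether chloro in place of hydrogen would give a similar step with the other groups on the shared core changed.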